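This account rests on a few compounds, and the source may have more. Where it says the series, first, only, none or still open, it means among the compounds named here.

Working notes on the cinnamamide series.

Compound 1 `COc1cc(/C=C/C(=O)NCCn2c(C)cc3ccccc32)cc(OC)c1` carries two methoxy groups on the aromatic ring attached to the alkene. In an assay on C6 cells for antagonist activity at prostaglandin E2 receptor EP2 subtype (Homo sapiens), read by TR-FRET, with stated times of 10 min and 40 min, tested at 1 uM (a higher number here means a weaker inhibitor, a lower number a stronger inhibitor), compound 1 gives 3.4 nM. For the measured compounds named here, the only other measured member is compound 2 `COc1cc(C(N)CC(=O)NCCn2c(C)cc3ccccc32)cc(OC)c1OC`, which in this assay gives 410 nM; it differs from compound 1 in more than one place, so no single step is defined between them. Of the two numbers, compound 1 has the lower one, and the gap to compound 2 lies well beyond the scatter.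

Compound 3 `COc1cccc(/C=C/C(=O)NCCn2c(C)cc3ccccc32)c1` is yet to be measured in this assay. Relative to compound 1 the change is hydrogen in place of methoxy on an aromatic carbon, with the remaining methoxy and the whole amide-linked core untouched. Going by the values given here, no measured pair in the set isolates this change, so the expectation rests on compound 1 alone. The expected step of a 2.9-fold higher number from compound 1 to compound 3 (0.47 log units; beyond the scatter) is a modest rise in the number, somewhat beyond the scatter, since the two methoxy groups are a recurring feature of the stronger compound here. Compound 3 is accordingly estimated at 10 nM, with a likely range from 3 nM to 40 nM.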

Compound 3, antagonist equilibrium constant: 29.2 nM
Compound 3: the middle estimate sits 2.9-fold (0.47 log units) below what was measured; the measured number falls inside the stated range.
By their numbers in this assay, from the lowest: compound 1; then compound 3; then compound 2.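

In an 8.6-fold higher number from compound 1 to compound 3 (0.93 log units; beyond the scatter), this assay gives the series its first step that can be read in one place: hydrogen in place of methoxy on an aromatic carbon, meta to a methoxy group. The one methoxy therefore counts on its own, since the number moves beyond the scatter while the remaining methoxy and the rest of the structure stay as they are, something the comparison of compound 1 with compound 2, which differ in more than one place, could not show. Nothing in the data on hand bears on the reason for this step.

Still open, going by these compounds, is what a replacement other than hydrogen would do at this aromatic carbon: a hydroxyl, a fluorine or a longer ether such as ethoxy could each keep the number close to that of compound 1 or move it further away. Also open, on these data alone, is whether replacing the remaining methoxy with hydrogen would add a second rise of similar size, or whether the step seen here depends on that methoxy being present.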